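The compounds below may be only part of what the source reports. "The series", "measured", "known", "first", "only" and "open" are said of these compounds alone.

In a functional assay on HL-60 cells (Homo sapiens) for antiproliferative activity, with a stated time of 72 h (on this read-out lower numbers stand for stronger inhibition and higher numbers for weaker inhibition), compound 1 `Cc1ccc(CNc2ncnc3c2ncn3[C@@H]2O[C@H](CO)[C@@H](O)[C@H]2O)cc1` reads > 166000 nM, which is a limit. Within the data shown here, compound 2 `OC[C@H]1O[C@@H](n2cnc3c(NCc4ccc(F)cc4Cl)ncnc32)[C@H](O)[C@@H]1O` gives 9000 nM, the only actual number so far. Among the measured compounds shown here, the single measured step, an at least 18-fold lower number from compound 1 to compound 2 (1.26 log units; beyond the scatter), is large but rests on (the limit of > 166000 nM in this assay, at which 1 of the 2 values shown sits). Compound 3 `OC[C@H]1O[C@@H](n2cnc3c(NCc4ccc(F)c(Cl)c4)ncnc32)[C@H](O)[C@@H]1O` differs from compound 2 by 3-chloro-4-fluorophenyl in place of 2-chloro-4-fluorophenyl on a saturated chain carbon bound to a nitrogen on an aromatic ring, with 3-chloro-4-fluorophenyl in place of 2-chloro-4-fluorophenyl. For the measured compounds named here, compound 1 lacks any chlorine, so an at least 18-fold lower number from compound 1 to compound 2 (1.26 log units; beyond the scatter) offers only weak guidance on this change, and no measured step tests it directly. In this assay, the expected result is a small move toward weaker inhibition, perhaps within the scatter, namely a 1.7-fold higher number from compound 2 to compound 3 (0.22 log units; within the scatter). Compound 3 is estimated at 15000 nM, with an expected range of 3000 nM to 70000 nM.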

Compound 3, half-maximal inhibitory concentration: 3500 nM
Beside the measured number, compound 3's estimate is 4.3-fold (0.63 log units) above it; the measured number falls inside the stated range.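

With the same atoms in both groups, 3-chloro-4-fluorophenyl in place of 2-chloro-4-fluorophenyl gives a 2.6-fold lower number from compound 2 to compound 3 (0.41 log units; beyond the scatter) in this assay, so the arrangement of the halogens on this ring changes the read-out, and not only their presence. Compound 1 stands at a limit, so an at least 47-fold lower number from compound 1 to compound 3 (1.67 log units; beyond the scatter) fixes only a bound on the size of this step: the limit of > 166000 nM in this assay, at which 1 of the 3 values shown sits.

As far as these compounds go, what a 3-chlorophenyl or a 4-fluorophenyl group alone would read here stays open, so the share of each halogen remains unknown. From the compounds shown here alone, the effect of a methoxy group or an amine on this ring is also open.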